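Azetidine replaced by a bare amino group on the shared core

The source may report more compounds than this note shows. Statements on the series, on what has been measured and on what is new or still open speak of the compounds shown alone.

Compound 1 `Fc1ccccc1Cn1cnc2c(NC3CCCC3)ncnc21` gives 8 mg/kg in a functional assay on the whole organism with Rattus norvegicus as the target, in the maximal electroshock model; on this read-out higher numbers stand for an effect only at larger amounts of compound and lower numbers for an effect already at smaller amounts.
Compound 2 `Fc1ccccc1Cn1cnc2c(N3CCC3)ncnc21` gives only > 50 mg/kg in this assay, which is a limit of the assay and not a number.

Among the measured compounds shown here, compound 2 therefore stands at the top of what was measured, and the one step that reaches it, an at least 6.2-fold higher number from compound 1 to compound 2 (0.79 log units; beyond the scatter), is capped by the limit of > 50 mg/kg in this assay, at which 1 of the 2 values shown sits. Compound 3 `Nc1ncnc2c1ncn2Cc1ccccc1F` differs from compound 2 by amino in place of azetidin-1-yl on an aromatic carbon. For the measured compounds named here, no measured step covers an amino group in this place, so the direction is open. Compound 3 is estimated at 35 mg/kg, with a range from 10 mg/kg to 120 mg/kg. That estimate means an expected step of an at least 1.4-fold lower number from compound 2 to compound 3 (0.15 log units; that floor lies within the scatter).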

Compound 3, dose for half-maximal effect: 4.5 mg/kg
Compound 3: middle estimate off by 7.8-fold (0.89 log units), on the high side; measured number below the stated range.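

In this assay, amino in place of azetidin-1-yl on this aromatic carbon gives an at least 11-fold lower number from compound 2 to compound 3 (1.04 log units; beyond the scatter), so a group as small as amino is enough here. Hydrogen in place of cyclopentyl gives a 1.8-fold lower number from compound 1 to compound 3 (0.25 log units; within the scatter), so the cyclopentyl group is not needed for this effect. Compound 2 carries a limit and not a number, which makes the first step a floor: the limit of > 50 mg/kg in this assay, at which 1 of the 3 values shown sits.

Azetidin-1-yl is the only one of these groups with no hydrogen on that nitrogen, but three compounds cannot show whether that hydrogen matters. Methylamino and dimethylamino at this place would test it.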